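A Benzylamide Pair Compared in the Electroshock Model

The source may report more compounds than this note shows. Statements on the series, on what has been measured and on what is new or still open speak of the compounds shown alone.

The two measured compounds share the benzylamide core. Compound 1 `C=CCOCC(N)C(=O)NCc1ccccc1` carries an allyloxymethyl side chain; in a functional assay on the whole organism (strain NMRI) with Mus musculus as the target, in the maximal electroshock model, with a stated time of 30 min (a higher number here means that more compound is needed for the effect, a lower number that less compound is needed), compound 1 gives 45 mg/kg. Compound 2 `CCC[C@H](N)C(=O)NCc1ccccc1` carries a 1-aminobutyl group on the carbonyl carbon. For compound 2 in this assay only a limit is reported, > 37 mg/kg, so where compound 2 truly stands is open; of the two values shown, one sits at this limit (the limit of > 37 mg/kg in this assay, at which 1 of the 2 values shown sits).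

Compound 3 `NCC(N)C(=O)NCc1ccccc1` differs from compound 2 in one place (1,2-diaminoethyl in place of 1-aminobutyl on a carbonyl carbon). Going by the values given here, no measured step connects two of the compounds here, so the size of the change can only be anticipated. With compound 2 giving just a limit > 37 mg/kg in this assay, the author expects compound 3 also to need a dose at the high end, with little or no movement beyond the scatter from compound 2; the step implied by the estimate is a step that the limit leaves unreadable from compound 2 to compound 3. Compound 3 is estimated at 60 mg/kg in this assay, within a range from 25 mg/kg to 150 mg/kg.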

Compound 3, dose for half-maximal effect: > 68 mg/kg
Compound 3: a limit, no number; the forecaster's own chance of this, stated with the estimate: 55%; at least 1.1-fold (0.05 log units) between middle value and limit.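

In this assay compound 3 gives > 68 mg/kg, which is a limit and not a number. Amino in place of allyloxy on a saturated chain carbon, two bonds along the chain from an amine nitrogen and a carbonyl carbon, gives an at least 1.5-fold higher number from compound 1 to compound 3 (0.17 log units; that floor lies within the scatter), so this change can be read only as a floor, and that floor does not separate the two compounds. The other change, 1,2-diaminoethyl in place of 1-aminobutyl on a carbonyl carbon, cannot be read at all, as compound 2 and compound 3 both stand at limits: the limit of > 68 mg/kg in this assay, at which 1 of the 3 values shown sits.

Where compound 2 and compound 3 truly stand in this assay remains open, and so does whether the amino group of compound 3 and the allyloxy group of compound 1 differ by more than the scatter. Also open, as far as these compounds go, is how a methoxy group or a carboxylic acid would read in place of that amino group on the saturated chain carbon.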